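Swapping methoxy for fluoro on a more polar core

This account rests on a few compounds, and the source may have more. Where it says the series, first, only, none or still open, it means among the compounds named here.

Measured so far:
- compound 1, `COc1ccc(/C=C/C(=O)OC[C@@H](OCc2ccccc2)[C@H]2OC(=O)C=C[C@H]2OCc2ccccc2)cc1`, gives 3260 nM
- compound 2, `O=C1C=C[C@@H](OCc2ccccc2)[C@@H]([C@@H](COC(=O)/C=C/c2ccc(F)cc2)OCc2ccccc2)O1`, gives 3580 nM
- compound 3, `COc1ccc(/C=C/C(=O)OC[C@@H](OC(C)=O)[C@H]2OC(=O)C=C[C@H]2OC(C)=O)cc1`, gives 22800 nM

All three were tested in a functional assay on MDA-MB-231 cells (Homo sapiens) for antiproliferative activity, read by MTT assay, with a stated time of 6 days; on this read-out lower numbers stand for stronger inhibition and higher numbers for weaker inhibition. Going by the values given here, compound 1 and compound 2 share one core, and the only change between them is fluoro in place of methoxy on an aromatic carbon. That change produced a 1.1-fold higher number from compound 1 to compound 2 (0.04 log units; within the scatter), so on this read-out the two compounds cannot be told apart.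

Compound 3 carries the same methoxy-bearing side chain as compound 1 but sits on a different core; the difference between the two cores is not broken down here. Compound 3 gives the highest number of the three, standing beyond the scatter from both compound 1 and compound 2.

Compound 4, `CC(=O)O[C@@H]1C=CC(=O)O[C@@H]1[C@@H](COC(=O)/C=C/c1ccc(F)cc1)OC(C)=O`, is the not yet measured partner of compound 3. The change from compound 3 to compound 4 is fluoro in place of methoxy on an aromatic carbon. The place of the change is described in the same words for both pairs, so this is the same change that turned compound 1 into compound 2, now made on the core of compound 3.

Because that earlier change produced a 1.1-fold higher number from compound 1 to compound 2 (0.04 log units; within the scatter), the expectation is that the same swap on the other core also leaves the number nearly unchanged, so compound 4 is estimated to show a 1.1-fold higher number from compound 3 to compound 4 (0.04 log units; within the scatter) in this assay. Compound 4 is therefore estimated at 25000 nM, with a range from 12000 nM to 50000 nM.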

Compound 4, half-maximal inhibitory concentration: 34400 nM
Compound 4: the middle estimate sits 1.4-fold (0.14 log units) below what was measured; low and high end bracket the measured number.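

In this assay, putting fluoro in place of methoxy on the core of compound 3 gives a 1.5-fold higher number from compound 3 to compound 4 (0.18 log units; within the scatter), so on this read-out compound 3 and compound 4 cannot be told apart. The same swap was already silent on the core of compound 1, and the two steps agree with each other: the same change on two cores in this assay, a 1.1-fold higher number (0.04 log units; within the scatter) from compound 1 to compound 2 and a 1.5-fold higher number (0.18 log units; within the scatter) from compound 3 to compound 4, 1.4-fold (0.14 log units) apart, within the scatter of two such steps. This shows that, for these two pairs, the swap carries from one core to the other without a step beyond the scatter, but it does not show that the swap would stay silent on a third core, in a different assay, or why the two steps agree.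

Going by these compounds alone, with only two pairs, and only methoxy and fluoro on the aromatic ring, this is a small base for any general rule about the series. From the compounds shown here alone, it remains open whether a group of another kind in that same place, such as an amine, a carboxylic acid or a nitrile, would also leave the number within the scatter, or whether it would behave differently from one core to the other.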